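The source may hold more compounds than are shown below. What is called first, only, known or untested is meant among the compounds shown, and "the series" means these compounds.

Working notes on the series.

Three compounds of this series have numbers in an assay on isolated protein for inhibition of protein kinase C theta type (Homo sapiens), read by TR-FRET, with a stated time of 2 h (on this read-out lower numbers stand for stronger inhibition and higher numbers for weaker inhibition), so far. Compound 1 `N#Cc1cnc(NCc2cnccc2C(F)(F)F)cc1N[C@H]1C[C@@H](O)C1` gives 500 nM in this assay. Compound 2 `N#Cc1cnc(NCc2ccccc2C(F)(F)F)cc1N[C@H]1C[C@H](C(N)=O)C1` gives 5000 nM, and compound 3 `CC(C)(C)Oc1ncncc1CNc1cc(N[C@H]2CC[C@@H](O)CC2)c(C#N)cn1` gives 200 nM. On these numbers compound 1 stands second highest of the three: compound 3 is the nearest to it, with a lower number, and compound 2 the furthest, with a higher number, and both gaps lie beyond the usual scatter of this assay.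

The next compound to be measured is compound 4 `CC1(C)C[C@@H](Nc2cc(NCc3cnccc3C(F)(F)F)ncc2C#N)CC[C@@H]1O`. Relative to compound 1 the change is 4-hydroxy-3,3-dimethylcyclohexyl in place of 3-hydroxycyclobutyl on a nitrogen on an aromatic ring. The shared core and the amine-linked side chain of compound 1 are kept; only the substituent on that ring nitrogen is exchanged.

For the measured compounds named here, no step between measured compounds matches this exchange, so the direction must be read from the surrounding numbers alone. Compound 3, the only measured compound that also carries a six-membered hydroxylated carbocycle on that nitrogen, gives 200 nM, the lowest number shown, and this is taken as the main hint. A modest step toward a lower number is therefore expected, and the step from compound 1 to compound 4 is estimated as a 2.0-fold lower number from compound 1 to compound 4 (0.30 log units; within the scatter). For compound 4 the estimate in this assay is 250 nM, with a range from 80 nM to 800 nM.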

Compound 4, half-maximal inhibitory concentration: 120 nM
Beside the measured number, compound 4's estimate is 2.1-fold (0.32 log units) above it; measured number inside the range.
By their numbers in this assay, from the lowest: compounds 4 and 3 (each within the scatter of the next); then compound 1; then compound 2.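

For the compounds shown here, until now the series held no step that changes one place only. With the shared core and the amine-linked side chain of compound 1 kept, exchanging 3-hydroxycyclobutyl for 4-hydroxy-3,3-dimethylcyclohexyl on a nitrogen on an aromatic ring gives a 4.2-fold lower number from compound 1 to compound 4 (0.62 log units; beyond the scatter) in this assay, so this position accepts the larger six-membered ring with its 3,3-dimethyl substitution and responds to the exchange with a lower number. The hydrogen-bond donor and acceptor counts of the substituent stay as they were, and nothing at hand accounts for the size or direction of the step.

The exchange alters ring size and adds the 3,3-dimethyl substitution together, so the shares of the two in the step cannot be separated on these numbers. Also open, as far as these compounds go, is how this assay would read with an amine or a carboxylic acid in place of the hydroxy group on the six-membered ring.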